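The source may hold more compounds than are shown below. What is called first, only, known or untested is meant among the compounds shown, and "the series" means these compounds.

Of the compounds shown here, two built on the same fused core have been measured in an assay for binding affinity to Neuronal acetylcholine receptor; alpha4/beta2 (Rattus norvegicus); on this read-out higher numbers stand for weaker inhibition and lower numbers for stronger inhibition. Compound 1 `COc1ccc2cc3c(cc2n1)C1CNCC3C1` carries a methoxy group and in this assay compound 1 gives 30 nM. Compound 2 `CCc1cnc2cc3c(cc2c1)C1CNCC3C1` carries an ethyl group instead, at a different place on the core, and in this assay compound 2 gives 1.2 nM. Of the two numbers, compound 2 has the lower one, and the gap to compound 1 lies well beyond the usual scatter of repeated measurements.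

Compound 3 `c1cnc2cc3c(cc2c1)C1CNCC3C1` has not yet been measured. It differs from compound 2 in one place: hydrogen in place of ethyl on an aromatic carbon. Going by the values given here, the only other measured compound differs from compound 2 elsewhere, so no measured step shows what taking away the ethyl group does here. Taking the ethyl away seems likely to cost some affinity, because compound 2 with that group gives 1.2 nM, the lowest number seen. For compound 3 the estimate is 5 nM, in a range from 1 nM to 25 nM. This estimate means an expected step of a 4.2-fold higher number from compound 2 to compound 3 (0.62 log units; beyond the scatter), slightly beyond the scatter toward a higher number.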

Compound 3, inhibition constant: 1.6 nM
Compound 3: the middle estimate sits 3.1-fold (0.49 log units) above what was measured; measured number inside the range.
By their numbers in this assay, from the lowest: compounds 2 and 3 (each within the scatter of the next); then compound 1.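

In this assay, putting hydrogen in place of ethyl gives a 1.3-fold higher number from compound 2 to compound 3 (0.12 log units; within the scatter) and so shows that the low number of compound 2 does not depend on the ethyl group: on this aromatic carbon, two atoms from the ring nitrogen, the two compounds cannot be told apart. Putting hydrogen in place of the methoxy group of compound 1 gives a 19-fold lower number from compound 1 to compound 3 (1.27 log units; beyond the scatter) and so shows a large difference, which links the higher number of compound 1 to its methoxy group at its own place on the shared core rather than to the core itself. No measurement here offers an explanation for either step.

These compounds do not tell whether this carbon would accept every group equally, since a longer chain such as propyl, an amine or a carboxylic acid could behave quite differently from ethyl and hydrogen. They also leave open whether a methoxy group on the carbon that carries ethyl in compound 2, or an ethyl group where compound 1 carries its methoxy, would follow the same pattern.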